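Swapping the small heteroaryl on the thiazole core for a larger one

This account rests on a few compounds, and the source may have more. Where it says the series, first, only, none or still open, it means among the compounds named here.

Three compounds share a core carrying a bis(4-fluorophenyl)methyl group and a carboxymethyl group, differing only in the aromatic ring attached on an aromatic carbon of the core. Compound 1 `NS(=O)(=O)c1ccc(-c2nc(C(c3ccc(F)cc3)c3ccc(F)cc3)sc2CC(=O)O)cc1` carries a 4-sulfamoylphenyl group, and in an in vitro assay on HEK385-7 cells for displacement of a labelled ligand from prostaglandin D2 receptor 2 (Homo sapiens) (a lower number here means a stronger inhibitor, a higher number a weaker inhibitor), compound 1 gives 1500 nM. Compound 2 `O=C(O)Cc1sc(C(c2ccc(F)cc2)c2ccc(F)cc2)nc1-c1ccco1` carries a furan-2-yl group and gives 18 nM; compound 3 `O=C(O)Cc1sc(C(c2ccc(F)cc2)c2ccc(F)cc2)nc1-c1cn[nH]c1` carries a 1H-pyrazol-4-yl group and gives 16 nM. The steps of an 83-fold lower number from compound 1 to compound 2 (1.92 log units; beyond the scatter) and a 94-fold lower number from compound 1 to compound 3 (1.97 log units; beyond the scatter) are both large, while a 1.1-fold lower number from compound 2 to compound 3 (0.05 log units; within the scatter) lies within the scatter, so compound 3 has the lowest number of the three but cannot be separated from compound 2.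

Compound 4 `O=C(O)Cc1sc(C(c2ccc(F)cc2)c2ccc(F)cc2)nc1-c1ccnc(N2CCCC2)c1` is not yet measured. Its change from compound 3 is 2-(pyrrolidin-1-yl)pyridin-4-yl in place of 1H-pyrazol-4-yl on an aromatic carbon. Among the measured compounds shown here, no measured step replaces a five-membered ring by a six-membered one bearing a ring, so the direction is uncertain; the only step toward a larger aromatic group, seen in reverse as a 94-fold lower number from compound 1 to compound 3 (1.97 log units; beyond the scatter), hurt potency. A moderate rise in the number is therefore expected, and compound 4 is estimated at 60 nM (range 12 nM to 300 nM), a step of a 3.8-fold higher number from compound 3 to compound 4 (0.57 log units; beyond the scatter) that is expected to exceed the scatter.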

Compound 4, half-maximal inhibitory concentration: 230 nM
Compound 4: the middle estimate sits 3.8-fold (0.58 log units) below what was measured; measured number inside the range.
By their numbers in this assay, from the lowest: compounds 3 and 2 (each within the scatter of the next); then compound 4; then compound 1.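

Moving to a six-membered aromatic ring that carries a second ring costs potency against both small five-membered rings in this assay, with a 14-fold higher number from compound 3 to compound 4 (1.16 log units; beyond the scatter) and a 13-fold higher number from compound 2 to compound 4 (1.11 log units; beyond the scatter). Yet this is not the full loss seen with the 4-sulfamoylphenyl group, since there is still a 6.5-fold lower number from compound 1 to compound 4 (0.81 log units; beyond the scatter). This position therefore shows three levels rather than two: a larger aromatic group can be tolerated to different degrees depending on what it is and what it carries. Nothing available explains these differences.

The compounds shown leave open whether the loss follows the six-membered ring itself or the pyrrolidin-1-yl group on it. A plain pyridin-4-yl group at this carbon would separate the two.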